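The source may report more compounds than this note shows. Statements on the series, on what has been measured and on what is new or still open speak of the compounds shown alone.

Notes on the series, read in a functional assay on MNK45 cells (Homo sapiens) for inhibition, read by MTT assay, with a stated time of 48 h; a lower number here means a stronger inhibitor, a higher number a weaker inhibitor.

Compound 1 `Cc1ccc(NC(=S)NC(=O)c2ccc(OCc3cccc(Cl)c3Cl)cc2)cc1-c1nc2ccccc2[nH]1` gives > 100000 nM in this assay, a limit of the assay rather than a number, and it sits at the limit of > 100000 nM in this assay, at which 1 of the 3 values shown sits. Compound 2 `Cc1ccc(COc2ccc(C(=O)NC(=S)Nc3ccc(C)c(-c4nc5ccccc5[nH]4)c3)cc2)cc1` gives 11300 nM. The change between them is 4-methylphenyl in place of 2,3-dichlorophenyl on a saturated chain carbon bound to an oxygen on an aromatic ring, and it made a step of an at least 8.8-fold lower number from compound 1 to compound 2 (0.94 log units; beyond the scatter); since compound 1 is at a limit, the true size of that step is not known.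

Compound 3 `Cc1ccc(NC(=O)NC(=O)c2ccc(OCc3cccc(Cl)c3Cl)cc2)cc1-c1nc2ccccc2[nH]1` gives 87000 nM, the highest of the two numbers shown. The difference between the core of compound 3 and the core of compound 1 is not broken down here.

Compound 4 `Cc1ccc(COc2ccc(C(=O)NC(=O)Nc3ccc(C)c(-c4nc5ccccc5[nH]4)c3)cc2)cc1` is not yet measured. It differs from compound 3 by 4-methylphenyl in place of 2,3-dichlorophenyl on a saturated chain carbon bound to an oxygen on an aromatic ring, the same change as that from compound 1 to compound 2, at the same place. For compound 4 the expected step is a 7.3-fold lower number from compound 3 to compound 4 (0.86 log units; beyond the scatter), resting on the step of an at least 8.8-fold lower number from compound 1 to compound 2 (0.94 log units; beyond the scatter) and on the value of compound 3, 87000 nM. Compound 4 is therefore estimated at 12000 nM, expected between 4000 nM and 40000 nM.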

Compound 4, half-maximal inhibitory concentration: 6360 nM
Compound 4: middle estimate off by 1.9-fold (0.28 log units), on the high side, and the stated range covers the measured number.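

In this assay, 4-methylphenyl in place of 2,3-dichlorophenyl on a saturated chain carbon bound to an oxygen on an aromatic ring gives a 14-fold lower number from compound 3 to compound 4 (1.14 log units; beyond the scatter). The change therefore lowers the number on both cores shown, and the two steps compare as follows: the same change on two cores in this assay, an at least 8.8-fold lower number (0.94 log units; beyond the scatter) from compound 1 to compound 2 and a 14-fold lower number (1.14 log units; beyond the scatter) from compound 3 to compound 4; the limit leaves it open whether they differ

Going by these compounds, compound 1 gives > 100000 nM, a limit of the assay and not a number; the size of the step on its core stays unknown, and two cores say nothing about whether the change would carry to any further core.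

The compounds shown leave open whether the lower numbers go with the loss of the two chlorines or with the arrival of the methyl, as 2,3-dichlorophenyl and 4-methylphenyl differ in both. Also open, on these data alone, is how an unsubstituted phenyl, an amine on the ring or a longer chain in the same place would read in this assay.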